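A Fluorine Enters Where the Methyl Moves Aside

A few compounds are considered here, and "the series" means these few. Any claim that something is new, unique, unknown or untested is made for them only; others in the source may bear on it.

Going by the values given here, compound 2 `CCC1=C(O)c2c(oc(-c3ccccc3C)cc2=O)C(CC)(CC)C1=O` stands at the lower end of the two numbers known in a functional assay on KBVIN cells (Homo sapiens) for antiproliferative activity, read by sulforhodamine B assay, with a stated time of 3 days; a higher number here means that more compound is needed for the effect, a lower number that less compound is needed: compound 2 gives 2.41 uM, while compound 1 `CCC1=C(O)c2c(oc(-c3ccc(Br)cc3)cc2=O)C(CC)(CC)C1=O` gives 15.7 uM. Among the compounds with values here, the single measured step, a 6.5-fold lower number from compound 1 to compound 2 (0.81 log units; beyond the scatter), is the only guide to changes of the aryl group at this position. Compound 3 `CCC1=C(O)c2c(oc(-c3cc(C)ccc3F)cc2=O)C(CC)(CC)C1=O` carries 2-fluoro-5-methylphenyl in place of 2-methylphenyl on an aromatic carbon. Within the data shown here, no measured step shows a fluorine entering this ring or the methyl shifting its place, so the guidance is thin. A modest step toward a higher number is expected, a 1.7-fold higher number from compound 2 to compound 3 (0.22 log units; within the scatter). Compound 3 is therefore estimated to give 4 uM, within 1.5 uM to 12 uM.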

Compound 3, concentration for half-maximal effect: 3.24 uM
The estimate for compound 3 lay 1.2-fold (0.09 log units) above the measured number; the measured number falls inside the stated range.
By their numbers in this assay, from the lowest: compounds 2 and 3 (each within the scatter of the next); then compound 1.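

In this assay, 2-fluoro-5-methylphenyl in place of 2-methylphenyl gives a 1.3-fold higher number from compound 2 to compound 3 (0.13 log units; within the scatter), so at this position the two changes together leave the number within the scatter. The difference from the 4-bromophenyl of compound 1 persists, with a 4.8-fold lower number from compound 1 to compound 3 (0.69 log units; beyond the scatter). No measurement offered here accounts for this result.

From the compounds shown here alone, since the fluorine and the altered methyl place arrive together, their separate contributions remain unknown. Going by these compounds, it also remains open how an amine or a carboxylic acid on this aryl ring would read in this assay.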